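The source may hold more compounds than are shown below. What is called first, only, known or untested is meant among the compounds shown, and "the series" means these compounds.

Measured so far:
Compound 1, `C#Cc1cn([C@@H]2O[C@H](CO)[C@@H](O)[C@H]2O)c2ncnc(OC)c12`, gives 98400 nM in an ADME assay on BJ cells (Homo sapiens), read by MTT assay, with a stated time of 72 h; on this read-out lower numbers stand for stronger inhibition and higher numbers for weaker inhibition.
Compound 2, `Cc1ncnc2c1c(-c1cccs1)cn2[C@@H]1O[C@H](CO)[C@@H](O)[C@H]1O`, reaches only the assay limit of > 100000 nM in this assay; this is a limit, not a number.
Compound 3, `COc1ncnc2c1c(-c1cccs1)cn2[C@@H]1O[C@H](CO)[C@@H](O)[C@H]1O`, gives 62800 nM in this assay.

Of the two numbers obtained, compound 3 has the lowest; the nearest is compound 1, and a 1.6-fold lower number from compound 1 to compound 3 (0.20 log units; within the scatter), so the two sit within the scatter of each other. For compound 2 only a limit exists: the limit of > 100000 nM in this assay, at which 1 of the 3 values shown sits.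

Compound 4, `COc1ncnc2c1c(-c1ccccc1)cn2[C@@H]1O[C@H](CO)[C@@H](O)[C@H]1O`, is still to be measured in this assay. It differs from compound 3 in one place: phenyl in place of thiophen-2-yl on an aromatic carbon. Among the compounds with values here, only one measured step touches this same position, a 1.6-fold lower number from compound 1 to compound 3 (0.20 log units; within the scatter), and it stayed within the scatter. The other step, an at least 1.5-fold lower number from compound 2 to compound 3 (0.20 log units; that floor lies within the scatter), concerns a different place on the shared core and rests on a floor, so it says little here. Two different groups at this position gave numbers within the scatter of each other, so a third group gives no reason to look for a step beyond the scatter. The step from compound 3 to compound 4 is therefore estimated as a 1.1-fold higher number from compound 3 to compound 4 (0.05 log units; within the scatter). Compound 4 is expected to give 70000 nM in this assay, with a range from 35000 nM to 140000 nM.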

Compound 4, half-maximal inhibitory concentration: > 100000 nM
Compound 4: a limit, no number (the forecaster's own chance of this, stated with the estimate: 30%); middle value at least 1.4-fold (0.15 log units) from the limit.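

On this aromatic carbon, phenyl in place of thiophen-2-yl gives an at least 1.5-fold higher number from compound 3 to compound 4 (0.20 log units; that floor lies within the scatter), so this change has only a floor and no true size, and even that floor does not clear the scatter. Phenyl in place of ethynyl gives an at least 1.0-fold higher number from compound 1 to compound 4 (0.00 log units; that floor lies within the scatter), a floor that says still less about how far apart these two groups lie. What is new is that a change at this position, and not only the change in the other place that separates compound 2 from compound 3, can end at a limit rather than a number in this assay: the limit of > 100000 nM in this assay, at which 2 of the 4 values shown sit.

The groups shown at this position are ethynyl and two aromatic rings, so it remains open whether an amine, a carboxylic acid or a longer alkyl chain on this carbon would give a number or a limit in this assay. Going by these compounds, it also remains open whether phenyl truly differs from thiophen-2-yl or ethynyl here, and a value for a compound with phenyl that gives a number rather than a limit would be needed to tell.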